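A few compounds are considered here, and "the series" means these few. Any claim that something is new, unique, unknown or untested is made for them only; others in the source may bear on it.

Of the compounds shown here, three sharing one core have been measured in a functional assay on K562 cells (Homo sapiens) for cytotoxicity, read by fluorescence, with a stated time of 72 h (on this read-out higher numbers stand for weaker inhibition and lower numbers for stronger inhibition), and they differ only in the group on an aromatic carbon between two ring nitrogen atoms. Compound 1 (`CC(C)c1n[nH]c2c(NCc3ccc(-c4ccccn4)cc3)nc(S(C)(=O)=O)nc12`), carrying methylsulfonyl there, gives 640 nM. Compound 2 (`CC(C)c1n[nH]c2c(NCc3ccc(-c4ccccn4)cc3)nc(N3CCCCC3CCO)nc12`), with 2-(2-hydroxyethyl)piperidin-1-yl, gives 165 nM, and compound 3 (`CC(C)c1n[nH]c2c(NCc3ccc(-c4ccccn4)cc3)nc(N[C@@H]3CCCC[C@H]3N)nc12`), with (2-aminocyclohexyl)amino, gives 175 nM. Compound 3 therefore stands level with compound 2, well under compound 1: the data show a 1.1-fold higher number from compound 2 to compound 3 (0.03 log units; within the scatter) and a 3.7-fold lower number from compound 1 to compound 3 (0.56 log units; beyond the scatter).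

Compound 4 (`CC(C)c1n[nH]c2c(NCc3ccc(-c4ccccn4)cc3)nc(N3CCNCC3)nc12`) has not yet been measured. It carries piperazin-1-yl in place of (2-aminocyclohexyl)amino on the same carbon: piperazin-1-yl in place of (2-aminocyclohexyl)amino on an aromatic carbon.

Within the data shown here, no measured compound carries piperazin-1-yl, so the guidance is indirect. Replacing methylsulfonyl gave two modest steps of similar size, a 3.9-fold lower number from compound 1 to compound 2 (0.59 log units; beyond the scatter) and a 3.7-fold lower number from compound 1 to compound 3 (0.56 log units; beyond the scatter). The two replacing groups, though quite different from each other, then stayed within the scatter of one another. On that basis, piperazin-1-yl is expected to stay near compound 3 too, with a slight allowance towards a higher number. The expected change is a 1.1-fold higher number from compound 3 to compound 4 (0.06 log units; within the scatter), which is no step beyond the scatter. For compound 4 the estimated value is 200 nM, with an expected range from 80 nM to 500 nM.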

Compound 4, half-maximal inhibitory concentration: 17 nM
Beside the measured number, compound 4's estimate is 12-fold (1.07 log units) above it; the whole stated range lies above it.
By their numbers in this assay, from the lowest: compound 4; then compounds 2 and 3 (each within the scatter of the next); then compound 1.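

In this assay, the group on this carbon now proves able to shift the number far more than compounds 2 and 3 suggested, since those two lie within the scatter of each other yet piperazin-1-yl gives a 10-fold lower number from compound 3 to compound 4 (1.01 log units; beyond the scatter) and a 9.7-fold lower number from compound 2 to compound 4 (0.99 log units; beyond the scatter). Set against the methylsulfonyl group, the step reaches a 38-fold lower number from compound 1 to compound 4 (1.58 log units; beyond the scatter), so what matters is not only that methylsulfonyl is replaced but also which ring takes its place. Piperazin-1-yl has 6 heavy atoms against 8 in (2-aminocyclohexyl)amino, 1 hydrogen-bond donor against 2, and no defined stereocentres against 2, but nothing available ties the drop in the number to any of these differences.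

The compounds shown leave open whether the second ring nitrogen of piperazin-1-yl is needed, a question that morpholin-4-yl, with an oxygen atom in that place, or 4-methylpiperazin-1-yl, with a methyl group on that nitrogen, could answer. They also leave open whether the ring itself counts, which an open-chain group such as 2-aminoethylamino could test.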